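Pyrazolyl to methoxy on a chloro-bearing core

A few compounds are considered here, and "the series" means these few. Any claim that something is new, unique, unknown or untested is made for them only; others in the source may bear on it.

Compound 1 `c1cc(-c2ccn[nH]2)c2c(c1)C(c1ncc[nH]1)CC2` gives 336 nM in a functional assay on CHO cells for agonist activity at Alpha-1D adrenergic receptor (Homo sapiens), read by FLIPR and calcium flux; on this read-out lower numbers stand for an effect already at smaller amounts and higher numbers for an effect only at larger amounts of compound. For compound 2 `COc1cccc2c1CCC2c1ncc[nH]1` the value of > 10000 nM in this assay is a limit of the assay, not a number. For compound 3 `Clc1ccc2c(c1-c1ccn[nH]1)CCC2c1ncc[nH]1` the value of > 10000 nM in this assay is likewise a limit. The change methoxy in place of 1H-pyrazol-5-yl on an aromatic carbon gave an at least 29-fold higher number from compound 1 to compound 2 (1.47 log units; beyond the scatter), and the change chloro in place of hydrogen on an aromatic carbon gave an at least 29-fold higher number from compound 1 to compound 3 (1.47 log units; beyond the scatter); both steps end at the limit of > 10000 nM in this assay, at which 2 of the 3 values shown sit.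

Compound 4 `COc1c(Cl)ccc2c1CCC2c1ncc[nH]1` awaits measurement in this assay. It differs from compound 3 by methoxy in place of 1H-pyrazol-5-yl on an aromatic carbon, the same kind of change as that from compound 1 to compound 2, the place now being ortho to a chloro group (1 heavy atom). Resting on an at least 29-fold higher number from compound 1 to compound 2 (1.47 log units; beyond the scatter), the expected step is a step that the limit leaves unreadable from compound 3 to compound 4, which would keep compound 4 at the limit. Compound 4 is thus expected near 30000 nM in this assay, with a range from 10000 nM to 100000 nM.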

Compound 4, half-maximal effective concentration: > 10000 nM
Compound 4: only a limit was reported; the forecaster's own chance of this, stated with the estimate: 90%; the middle value lies beyond the limit too.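

No step from compound 3 or compound 2 to compound 4 can be read, because all three compounds end at a limit, not a number: the limit of > 10000 nM in this assay, at which 3 of the 4 values shown sit.

From the compounds shown here alone, how far compound 2, compound 3 and compound 4 lie beyond that limit, and how they rank among themselves, stays open.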